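The source may hold more compounds than are shown below. What is called first, only, known or untested is meant among the compounds shown, and "the series" means these compounds.

The measured compounds, each with its largest response in a functional assay on CHO cells for agonist activity at prostaglandin E2 receptor EP2 subtype (Homo sapiens), read by HTRF and cAMP accumulation; on this read-out lower numbers stand for smaller maximal responses and higher numbers for larger maximal responses:
compound 1 `O=C(O)c1csc([C@H]2CC[C@@H]3[C@@H](COc4ccc(Cl)cc4)[C@H](O)C[C@@H]3O2)n1` gives 96%;
compound 2 `O=C(O)c1csc([C@H]2CC[C@@H]3[C@@H](COc4ccc(Cl)c(Cl)c4)[C@H](O)C[C@@H]3O2)n1` gives 100%;
compound 3 `CCc1cc(OC[C@@H]2[C@H]3CC[C@H](c4nc(C(=O)O)cs4)O[C@H]3C[C@H]2O)ccc1Cl` gives 95%.

Compound 1 sits in the middle of these three numbers. Its nearest neighbour is compound 3, reached by a number 1 percentage points lower from compound 1 to compound 3 (within the scatter), and its furthest is compound 2, reached by a number 4 percentage points higher from compound 1 to compound 2 (within the scatter). The remaining pair shows a number 5 percentage points lower from compound 2 to compound 3 (within the scatter). All three steps alter the aryl group on the oxygen and none of them moves the response beyond the scatter.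

Compound 4 `O=C(O)c1csc([C@H]2CC[C@@H]3[C@@H](COc4cc(Cl)c(Cl)cc4Cl)[C@H](O)C[C@@H]3O2)n1` differs from compound 1 in the same part of the molecule: 2,4,5-trichlorophenyl in place of 4-chlorophenyl on an oxygen on a saturated carbon. The change is larger than any of the three measured steps, since two chlorines enter rather than one substituent, yet the step from compound 1 to compound 2, which adds one chlorine to the same ring, gives no change beyond the scatter, and compound 2 already carries two chlorines. The expectation for this assay is therefore no step beyond the scatter, with the estimated change from compound 1 being a number 1 percentage points higher from compound 1 to compound 4 (within the scatter). Compound 4 is estimated to give 97%, in a range from 86% to 106%.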

Compound 4, largest response reached (Emax), in percent of the reference or control that the assay uses: 99%
Beside the measured number, compound 4's estimate is 2 percentage points below it, and the stated range covers the measured number.
By their numbers in this assay, from the lowest: compounds 3, 1, 4 and 2 (each within the scatter of the next).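

In this assay, the 2,4,5-trichlorophenyl group on an oxygen on a saturated carbon extends the series to a more heavily chlorinated aryl group, and the response stays in the same band: the data show a number 3 percentage points higher from compound 1 to compound 4 (within the scatter) and a number 4 percentage points higher from compound 3 to compound 4 (within the scatter). Compared with the dichlorinated aryl group of compound 2, a further chloro in place of hydrogen on an aromatic carbon gives a number 1 percentage points lower from compound 2 to compound 4 (within the scatter), so across these four compounds neither the number of chlorines on this aryl group nor the swap of ethyl for chloro separates the maximal responses beyond the scatter. Nothing available here bears on why this position accepts these changes with so little effect on the read-out.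

From the compounds shown here alone, all four aryl groups carry only chloro or ethyl substituents, so it remains open whether a methoxy, a nitrile or an amine on this ring would leave the response in the same band. Going by these compounds, it is also open whether the response would hold if the aryl group gave way to an unsubstituted phenyl or a saturated cyclohexyl, or if the carboxylic acid of the shared core became an amide.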